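This account rests on a few compounds, and the source may have more. Where it says the series, first, only, none or still open, it means among the compounds named here.

Measured so far in a functional assay on SW480 cells (Homo sapiens) for cytotoxicity, read by MTT assay, with a stated time of 72 h; a lower number here means a stronger inhibitor, a higher number a weaker inhibitor:
Compound 1 `O=c1cc(CSc2nc3ccccc3s2)oc2ccccc12` gives > 25000 nM, a limit of the assay.
Compound 2 `Cc1cc(C)nc(SCc2cc(=O)c3cc(Cl)ccc3o2)n1` gives > 25000 nM, a limit of the assay.
Compound 3 `O=c1cc(CSc2nc3ccccc3s2)oc2ccc(Cl)cc12` gives > 25000 nM, a limit of the assay.

None of the three compounds reached a measurable number in this assay; each sits at the limit of > 25000 nM in this assay, at which 3 of the 3 values shown sit. Compound 3 and compound 1 differ in one place, (hydrogen in place of chloro on an aromatic carbon), yet a step that the two limits leave unreadable from compound 3 to compound 1; both values are limits. Compound 2 carries a different core from compound 3, and the difference between the two cores is not broken down here. Compound 4 `Cc1cc(C)nc(SCc2cc(=O)c3ccccc3o2)n1` has not yet been tested in this assay. For the measured compounds named here, it differs from compound 2 by hydrogen in place of chloro on an aromatic carbon, the same change as the one from compound 3 to compound 1, made at a place described in the same words. Going by the values given here, that earlier change gave no readable step, and the starting point for the new one is itself only known by a limit, so nothing among the measured compounds points toward a strong inhibitor here. For compound 4 the expected step is a step that the limit leaves unreadable from compound 2 to compound 4. This expectation rests on compound 2, whose value > 25000 nM is a limit, and on a step that the two limits leave unreadable from compound 3 to compound 1. Compound 4 is therefore estimated at 30000 nM in this assay, with a likely range from 10000 nM to 100000 nM, and most likely it will again be reported only as a limit.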

Compound 4, half-maximal inhibitory concentration: > 25000 nM
Compound 4 was reported as a limit (the forecaster's own chance of this, stated with the estimate: 85%); the middle value is on the limit's open side.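

Compound 4 gives > 25000 nM in this assay, which is again a limit of the assay. Swapping chloro for hydrogen therefore yields no readable step from compound 2 to compound 4, and all four compounds sit at the same ceiling: the limit of > 25000 nM in this assay, at which 4 of the 4 values shown sit.

The compounds shown leave open whether the chloro group makes any difference in this assay, and what change to these structures would give a measurable value.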